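A cyclohexyl group on the amide-type nitrogen of compound 1

This account rests on a few compounds, and the source may have more. Where it says the series, first, only, none or still open, it means among the compounds named here.

In a functional assay on HeLa cells (Homo sapiens) for antiproliferative activity, read by MTT assay, with a stated time of 72 h (a lower number here means a stronger inhibitor, a higher number a weaker inhibitor), compound 1 (`O=C1COc2ccc(-c3cccc(NS(=O)(=O)c4ccc(F)cc4)c3)cc2N1`) gives > 40000 nM as its reading, a limit of the assay and not a number. Two relatives do give numbers. Compound 2 (`CC(C)N1C(=O)COc2ccc(-c3cnc(Cl)c(NS(=O)(=O)c4ccc(F)cc4)c3)cc21`) reads 5380 nM and compound 3 (`COc1cccc(N2C(=O)COc3ccc(-c4cnc5ccccc5c4)cc32)c1`) reads 11400 nM in this assay under the same conditions. Both carry a group on the amide-type nitrogen where compound 1 has hydrogen, though both also differ from compound 1 in other places, so neither isolates that change.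

Compound 4 (`O=C1COc2ccc(-c3cccc(NS(=O)(=O)c4ccc(F)cc4)c3)cc2N1C1CCCCC1`) makes the change alone, with cyclohexyl in place of hydrogen on an amide-type nitrogen in a ring. The expected result is a gain in potency (an at least 4.0-fold lower number from compound 1 to compound 4 (0.60 log units; beyond the scatter)). Among the compounds with values here, its size is uncertain because the only reading for compound 1 is a limit (> 40000 nM) and gives no fixed starting point. The estimated value for compound 4 is 10000 nM with an expected range from 2500 nM to 40000 nM as its upper end.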

Compound 4, half-maximal inhibitory concentration: 10800 nM
Estimate against measurement, compound 4: 1.1-fold (0.03 log units) below, within the range that was stated.
By their numbers in this assay, from the lowest: compounds 2, 4 and 3 (each within the scatter of the next, the first and the last beyond it). At a limit, above all of these: compound 1.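

In this assay, cyclohexyl in place of hydrogen on the amide-type nitrogen in a ring gives an at least 3.7-fold lower number from compound 1 to compound 4 (0.56 log units; beyond the scatter). This reading isolates the change, since compounds 2 and 3 also differ from compound 1 in other places, and it shows that a six-membered ring of carbon only is accepted at this position on the core of compound 1. The size of the step remains a lower bound because the reading for compound 1 is a limit and not a number: the limit of > 40000 nM in this assay, at which 1 of the 4 values shown sits.

As far as these compounds go, whether a methyl group, or a cyclohexyl ring carrying an amine or a carboxylic acid, would bring a similar gain on this nitrogen stays open. Also open, from the compounds shown here alone, is whether cyclohexyl would give a similar step on a core with another group in place of the fluorophenyl sulfonamide part.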